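A Ring Nitrogen Enters the Dichlorinated Aryl Group

The source may hold more compounds than are shown below. What is called first, only, known or untested is meant among the compounds shown, and "the series" means these compounds.

Of the compounds shown here, two have been measured so far: compound 1 `N#Cc1cnc(NC(=O)N2CCN(c3ccc(Cl)c(Cl)c3)CC2)s1` and compound 2 `Cc1cc(NC2CCN(C(=O)Nc3ncc(Cl)s3)C2)ccc1Cl`. In an ADME assay on HepG2 cells (Homo sapiens) for cytotoxicity, with a stated time of 48 h (on this read-out lower numbers stand for higher toxicity in this test and higher numbers for lower toxicity in this test), compound 1 gives 410 nM, and in this assay compound 2 gives 680 nM. Compound 1 carries the lowest of the two numbers, yet its gap to compound 2 lies within the usual scatter of this measurement, so the two cannot be ranked against each other. Going by the values given here, no pair of measured compounds differs in just one place, so there is no directly comparable step to lean on.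

The compound still to be tested is compound 3 `N#Cc1cnc(NC(=O)N2CCN(c3cnc(Cl)c(Cl)c3)CC2)s1`. It differs from compound 1 by 5,6-dichloropyridin-3-yl in place of 3,4-dichlorophenyl on an amine nitrogen in a ring. A ring of carbon only gives way to a ring with one hetero atom, while the two chlorine substituents stay. Among the compounds with values here, with no measured step of this kind to go by, the expected step of a 1.3-fold higher number from compound 1 to compound 3 (0.13 log units; within the scatter) is small, with no direction that reaches beyond the scatter. Compound 3 is therefore estimated at 550 nM, within a range from 200 nM to 1500 nM.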

Compound 3, half-maximal cytotoxic concentration in the HepG2 assay: 120 nM
Compound 3: middle estimate off by 4.6-fold (0.66 log units), on the high side, outside the stated range (below it).
By their numbers in the HepG2 assay, from the lowest: compound 3; then compounds 1 and 2 (each within the scatter of the next).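

Going by these compounds alone, in the HepG2 assay, this is the first comparison that changes one place only, and it shows that the aryl group on the amine nitrogen of the ring is sensitive to a single ring atom: with both chlorine substituents kept, 5,6-dichloropyridin-3-yl in place of 3,4-dichlorophenyl gives a 3.4-fold lower number from compound 1 to compound 3 (0.53 log units; beyond the scatter), which on this read-out means higher toxicity in this test. In a physicochemical assay for solubility, read by nephelometry, at pH 6.5 (on this read-out higher numbers stand for higher solubility and lower numbers for lower solubility), compound 1 gives < 1600 nM, which is a limit of the assay and not a number. In the physicochemical assay compound 3 gives < 1600 nM, which is also a limit, so the solubility step for this change cannot be read: the limit of < 1600 nM in the physicochemical assay, at which 2 of the 2 values shown sit.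

A single step on one core cannot show whether the ring nitrogen would lower the cytotoxicity number in the same way with other substituents on the ring, such as a methoxy group or fluorine in place of the two chlorine substituents. As far as these compounds go, how compound 1 and compound 3 actually compare in solubility also stays open.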